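Benzamide series: methoxy entering the benzoyl ring

This account rests on a few compounds, and the source may have more. Where it says the series, first, only, none or still open, it means among the compounds named here.

Measured so far:
compound 1, `O=C(CCc1cc(Cl)ccc1NC(=O)c1ccccn1)c1ccccc1`, 4500 nM
compound 2, `O=C(Nc1cccc(F)c1CN1C(=O)c2ccccc2C1=O)c1ccccn1`, > 100000 nM
compound 3, `O=C(Nc1ccc(Cl)cc1CN1C(=O)c2ccccc2C1=O)c1ccccc1`, > 100000 nM

In an assay on CHO cells for positive allosteric modulation of metabotropic glutamate receptor 5 (Homo sapiens), read by FLIPR (a higher number here means that more compound is needed for the effect, a lower number that less compound is needed), compound 1 gives 4500 nM, the only numeric result among the three. For compound 2 the value > 100000 nM is a limit of the assay, not a number. For compound 3 the value > 100000 nM is likewise a limit of the assay. Compound 3 therefore stands at the limit of > 100000 nM in this assay, at which 2 of the 3 values shown sit, and nothing more than that limit is known of it in this assay.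

Compound 4, `COc1cccc(C(=O)Nc2ccc(Cl)cc2CN2C(=O)c3ccccc3C2=O)c1`, has not yet been measured in this assay. It differs from compound 3 by methoxy in place of hydrogen on an aromatic carbon; read one bond further out, the benzoyl of compound 3 becomes a (3-methoxyphenyl)carbonyl in compound 4.

Going by the values given here, no pair of measured compounds differs in one place, so no measured step shows how this assay answers such a change. With compound 3 at a limit, the expectation is a step of no size beyond the scatter, in no particular direction. The step of an at least 1.2-fold lower number from compound 3 to compound 4 (0.09 log units; that floor lies within the scatter) is expected to be small. Compound 4 is estimated at 80000 nM, with a range from 15000 nM to 300000 nM, and most likely it too returns only a limit.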

Compound 4, half-maximal effective concentration: 1500 nM
Compound 4: middle estimate off by 53-fold (1.73 log units), on the high side, outside the stated range (below it).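

In this assay, the benzoyl ring of compound 3 proves to be a place that responds strongly: methoxy in place of hydrogen on an aromatic carbon, meta to a large group, brings an at least 66-fold lower number from compound 3 to compound 4 (1.82 log units; beyond the scatter). With this change, the core shared by compound 3 and compound 4 yields a numeric result, as compound 4 gives 1500 nM in this assay. The true size of the step remains unknown, because compound 3 has only a limit of the assay and not a number: the limit of > 100000 nM in this assay, at which 2 of the 4 values shown sit.

From the compounds shown here alone, it remains open whether this response belongs to methoxy itself or would also follow from another group on the same carbon, such as fluorine, methyl, hydroxy or ethoxy. This single step gives no cause for the change and establishes no pattern, so it also leaves open whether methoxy would bring a comparable step on the benzoyl of compound 1 or on the pyridine ring of compound 2.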